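Methoxy in place of trifluoromethyl: compound 1 to compound 4

A few compounds are considered here, and "the series" means these few. Any claim that something is new, unique, unknown or untested is made for them only; others in the source may bear on it.

Three compounds of this series have been run through a functional assay on the whole organism with Rattus norvegicus as the target, with a stated time of 5 days (a higher number here means that more compound is needed for the effect, a lower number that less compound is needed), so far. Compound 1 `CN1CCC/C1=N\C(=O)Nc1cccc(C(F)(F)F)c1` gives only a limit in this assay, > 25 mg/kg, so no number is known for it. Compound 2 `COc1cccc(OC)c1NC(=O)/N=C1\CCCN1C` likewise reaches only a limit, > 25 mg/kg. Within the data shown here, compound 3 `CCN1CCC/C1=N\C(=O)Nc1cccc(Cl)c1` is the one member with a measured dose, 15 mg/kg. Compound 1 therefore stands at the limit of > 25 mg/kg in this assay, at which 2 of the 3 values shown sit, and nothing beyond that limit can be said of how it compares with compound 3.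

The next compound, compound 4 `COc1cccc(NC(=O)/N=C2\CCCN2C)c1`, differs from compound 1 in one place: methoxy in place of trifluoromethyl on an aromatic carbon. Among the measured compounds shown here, no measured pair shows this change, so there is no step to lean on. Given that compound 1 sits at > 25 mg/kg, the expectation for the step that the limit leaves unreadable from compound 1 to compound 4 is that it stays within the usual scatter, with a fair chance that compound 4 again returns only a limit rather than a number. Compound 4 is estimated at 30 mg/kg in this assay, within a range from 12 mg/kg to 75 mg/kg.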

Compound 4, minimum effective dose: > 25 mg/kg
Compound 4: only a limit was reported (the forecaster's own chance of this, stated with the estimate: 55%); the middle value does not contradict the limit.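

Compound 1 and compound 4 both return only a limit in this assay, so no step between them can be read for methoxy in place of trifluoromethyl: the limit of > 25 mg/kg in this assay, at which 3 of the 4 values shown sit.

The compounds shown leave open whether this replacement on the aromatic carbon changes the dose needed at all, and in which direction.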